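The source may report more compounds than this note shows. Statements on the series, on what has been measured and on what is new or still open speak of the compounds shown alone.

For the measured compounds named here, in an assay on lysate for inhibition of phosphatidylcholine:ceramide cholinephosphotransferase 2 (Homo sapiens), read by HPLC, with stated times of 30 min and 2 h (a lower number here means a stronger inhibitor, a higher number a weaker inhibitor), compound 1 `O=C(NCc1ccco1)c1ccccc1OCc1ccccc1` gives 49000 nM, and compound 2 `O=C(NC1CCCCC1)c1ccccc1OCc1ccccc1` gives 43400 nM; the one recorded step, a 1.1-fold lower number from compound 1 to compound 2 (0.05 log units; within the scatter), concerns the amide-type nitrogen only. Compound 3 `O=C(Nc1cccnc1)c1ccccc1OCc1ccccc1F` gives 3500 nM in this assay, the lowest of the three numbers, with compound 2 nearest and compound 1 furthest, both beyond the scatter. Compound 4 `N#Cc1cccc(COc2ccccc2C(=O)Nc2cccnc2)c1` differs from compound 3 by 3-cyanophenyl in place of 2-fluorophenyl on a saturated chain carbon bound to an oxygen on an aromatic ring, on a saturated chain carbon bound to an oxygen on an aromatic ring. Going by the values given here, no measured step touches this part of the shared core, so nothing here speaks for a change beyond the scatter in either direction. The step from compound 3 to compound 4 is therefore expected to be a 1.1-fold higher number from compound 3 to compound 4 (0.06 log units; within the scatter). Compound 4 is estimated at 4000 nM, between 1200 nM and 13000 nM.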

Compound 4, half-maximal inhibitory concentration: 60700 nM
Compound 4: middle estimate off by 15-fold (1.18 log units), on the low side; measured number above the stated range.
By their numbers in this assay, from the lowest: compound 3; then compounds 2, 1 and 4 (each within the scatter of the next).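

In this assay the group on a saturated chain carbon bound to an oxygen on an aromatic ring proves able to move the number strongly: 3-cyanophenyl in place of 2-fluorophenyl gives a 17-fold higher number from compound 3 to compound 4 (1.24 log units; beyond the scatter) as a large step beyond the scatter. For the compounds shown here, the only earlier step, at the amide-type nitrogen, stayed within the scatter. Nothing at hand bears on why this change costs so much. As far as these compounds go, it remains open whether the nitrile's entry or the fluorine's departure drives the step, and whether a plain phenyl or an aminophenyl at this place would hold the number of compound 3.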